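The source may hold more compounds than are shown below. What is called first, only, known or untested is meant among the compounds shown, and "the series" means these compounds.

Measured so far in an assay on CHO cells for displacement of a labelled ligand from adenosine receptor A3 (Homo sapiens), read by scintillation counting, with a stated time of 45 min, tested at 1 uM, in the presence of a further agent that is not named here; a higher number here means more inhibition at the concentration tested (going by the name of the read-out), a lower number less inhibition:
compound 1 `CCCn1c(=O)[nH]c2nc(-c3ccc(S(=O)(=O)N4CCN(c5ccc(F)cc5)CC4)cc3)[nH]c2c1=O` — 38%
compound 2 `CCCn1c(=O)[nH]c2nc(-c3ccc(S(=O)(=O)N4CCN(c5ccc(C)cc5)CC4)cc3)[nH]c2c1=O` — 25%
compound 3 `CCCn1c(=O)[nH]c2nc(-c3ccc(S(=O)(=O)N4CCN(C(C)c5ccccc5)CC4)cc3)[nH]c2c1=O` — 0%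

Compound 3 stands lowest of the three; its nearest neighbour is compound 2 a number 25 percentage points lower from compound 2 to compound 3 (beyond the scatter), and its furthest is compound 1 a number 38 percentage points lower from compound 1 to compound 3 (beyond the scatter). The step from compound 1 to compound 2 was a number 13 percentage points lower from compound 1 to compound 2 (beyond the scatter).

Compound 4 `CCCn1c(=O)[nH]c2nc(-c3ccc(S(=O)(=O)N4CCN(Cc5ccc(Br)cc5)CC4)cc3)[nH]c2c1=O` differs from compound 3 as follows: 4-bromobenzyl in place of 1-phenylethyl on an amine nitrogen in a ring. Among the compounds with values here, both measured steps that end at compound 3 replaced a directly attached aryl group on the ring nitrogen with 1-phenylethyl and lowered the read-out; no measured pair exchanges one carbon-linked benzylic group for another, so the present change has no direct precedent here. The expectation is therefore a small step, if any, and an estimated change of a number 8 percentage points higher from compound 3 to compound 4 (within the scatter) for compound 4, which is likely within the scatter. Compound 4 is thus estimated at 8%, in the range 0% to 25%.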

Compound 4, a percentage reported as inhibition, at one concentration (the size of the read-out at that concentration, not a potency): 28%
Beside the measured number, compound 4's estimate is 20 percentage points below it, outside the stated range (above it).
By their numbers in this assay, from the lowest: compound 3; then compounds 2, 4 and 1 (each within the scatter of the next, the first and the last beyond it).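

In this assay a carbon-linked benzylic group on the amine nitrogen in the ring does not by itself abolish the read-out: a number 28 percentage points higher from compound 3 to compound 4 (beyond the scatter) with 4-bromobenzyl in place of 1-phenylethyl. Set against the directly attached aryl groups, 4-bromobenzyl shows no separation, with a number 3 percentage points higher from compound 2 to compound 4 (within the scatter) and a number 10 percentage points lower from compound 1 to compound 4 (within the scatter) as its two steps. No measured evidence bears on the cause of these steps.

From the compounds shown here alone, whether the recovery rests on the bromine or on the loss of the branch in 1-phenylethyl stays open. A plain benzyl on this nitrogen would separate the two.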